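Chloro for acetyl on the pyridine of compound 2

The source may hold more compounds than are shown below. What is called first, only, known or untested is meant among the compounds shown, and "the series" means these compounds.

Measured so far in an assay on cells for inhibition of MAP kinase-interacting serine/threonine-protein kinase 1 (Homo sapiens), read by mobility shift assay, with stated times of 10 min and 60 min, in the presence of a further agent that is not named here; on this read-out lower numbers stand for stronger inhibition and higher numbers for weaker inhibition:
- compound 1 `CCOc1cc(-c2cccnc2)ccc1C(N)=O`: 2200 nM
- compound 2 `CC(=O)c1cncc(-c2ccc(C(N)=O)cc2)c1`: 8000 nM

Among the compounds with values here, compound 2 has the highest of the two numbers in this assay; compound 1, the only other measured compound, sits at a lower number, and that gap is beyond the usual scatter. Compound 3 `NC(=O)c1ccc(-c2cncc(Cl)c2)cc1` takes compound 2 and makes one change: chloro in place of acetyl on an aromatic carbon. Within the data shown here, no measured pair shows this exchange, so no size of step can be read from the data. Compound 3 is estimated at 5000 nM (range 1500 nM to 15000 nM). The step expected is a 1.6-fold lower number from compound 2 to compound 3 (0.20 log units; within the scatter), not beyond the scatter.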

Compound 3, half-maximal inhibitory concentration: 14200 nM
Beside the measured number, compound 3's estimate is 2.8-fold (0.45 log units) below it; the measured number falls inside the stated range.
By their numbers in this assay, from the lowest: compound 1; then compounds 2 and 3 (each within the scatter of the next).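

Chloro in place of acetyl on this aromatic carbon, two atoms from the ring nitrogen, gives a 1.8-fold higher number from compound 2 to compound 3 (0.25 log units; within the scatter). The acetyl, with its carbonyl and its hydrogen-bond acceptor, can therefore be exchanged for a single chlorine atom without a step beyond the scatter. No measured evidence bears on the reason for this outcome.

Only these two groups are compared at this position, so its wider scope cannot be read. Going by these compounds, whether an amine or a carboxylic acid on the same carbon would give a step beyond the scatter remains open.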